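Cytotoxicity notes on the shared-core series, compounds 1 to 4

The source may hold more compounds than are shown below. What is called first, only, known or untested is meant among the compounds shown, and "the series" means these compounds.

Measured so far in an ADME assay on cells (Homo sapiens) for cytotoxicity, read by polymerase chain reaction, with a stated time of 3 days; a higher number here means that more compound is tolerated, a lower number that less compound is tolerated:
- compound 1, `COc1ccc2nc(-c3c(Cl)nc(N)nc3N[C@@H]3C[C@H](CO)[C@@H](O)[C@H]3O)sc2c1`: compound 1 gives > 25000 nM, a limit of the assay and not a number.
- compound 2, `CNc1ccc2sc(-c3c(Cl)nc(N)nc3N[C@@H]3C[C@H](CO)[C@@H](O)[C@H]3O)nc2c1`: compound 2 gives 20000 nM.
- compound 3, `CCNc1nc(C)c(-c2nc3ccccc3s2)c(N[C@@H]2C[C@H](CO)[C@@H](O)[C@H]2O)n1`: compound 3 gives 12000 nM.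

Compound 3 holds the lowest of the two numbers measured in this assay. The nearest is compound 2, whose number is higher by a margin within the usual scatter of repeated measurements, so no order between compound 2 and compound 3 can be stated. For compound 1 only a limit is known; one of the three values sits at that limit (the limit of > 25000 nM in this assay, at which 1 of the 3 values shown sits).

Compound 4, `Cc1nc(NCc2cccs2)nc(N[C@@H]2C[C@H](CO)[C@@H](O)[C@H]2O)c1-c1nc2ccccc2s1`, is not yet measured. It differs from compound 3 by thiophen-2-yl in place of methyl on a saturated chain carbon bound to a nitrogen on an aromatic ring. Within the data shown here, no step between two measured compounds isolates a change of this kind, so there is no measured step to calibrate it against. In this assay the step of a 1.5-fold lower number from compound 3 to compound 4 (0.18 log units; within the scatter) is expected to be small and downward, not clearly beyond the scatter. Compound 4 is therefore estimated to give 8000 nM, with the expected range running from 3000 nM to 25000 nM.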

Compound 4, half-maximal cytotoxic concentration: 6000 nM
Estimate against measurement, compound 4: 1.3-fold (0.12 log units) above; the measured number falls inside the stated range.
By their numbers in this assay, from the lowest: compounds 4, 3 and 2 (each within the scatter of the next, the first and the last beyond it). At a limit, above all of these: compound 1.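

Among these compounds, replacing methyl with thiophen-2-yl on a saturated chain carbon bound to a nitrogen on an aromatic ring gives, in this assay, a 2.0-fold lower number from compound 3 to compound 4 (0.30 log units; within the scatter), the first step that isolates a single change. This place therefore takes a five-membered aromatic ring with a sulfur atom in place of the end of an ethyl group without a shift that can be told apart from repeat scatter, although this one step, resting on a single pair, fixes no trend. Compound 1 remains the only compound held at a limit of the assay rather than a number, and the reading of this step does not depend on it: the limit of > 25000 nM in this assay, at which 1 of the 4 values shown sits.

As far as these compounds go, whether a phenyl ring, a longer alkyl chain or a terminal amine at this same place would move the tolerated concentration clearly beyond the scatter stays open. From the compounds shown here alone, compound 1 and compound 2 differ from compound 3 and compound 4 in more than one place, so it also stays open whether thiophen-2-yl would give a similar step on their substitution pattern.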